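Trifluoromethyl on the Pendant Phenyl of a Chromone Acetamide

The compounds below may be only part of what the source reports. "The series", "measured", "known", "first", "only" and "open" are said of these compounds alone.

Compound 1 `CC(=O)Nc1ccc2oc(-c3ccccc3)cc(=O)c2c1` gives 97000 nM in an ADME assay on THP-1 cells (Homo sapiens) for cytotoxicity, read by flow cytometry and propidium iodide staining, with a stated time of 72 h; a lower number here means a stronger inhibitor, a higher number a weaker inhibitor.
Compound 2 `COc1ccccc1-c1cc(=O)c2cc(NC(C)=O)ccc2o1` gives 50000 nM in this assay.
Compound 3 `COc1cccc(-c2cc(=O)c3cc(NC(C)=O)ccc3o2)c1` gives 10000 nM in this assay.

Among the three measured compounds, compound 1 carries the highest number, so it is the weakest inhibitor of the set. Its nearest neighbour is compound 2, reached by a 1.9-fold lower number from compound 1 to compound 2 (0.29 log units; within the scatter), a step that stays within the scatter. Compound 3 lies further away: a 9.7-fold lower number from compound 1 to compound 3 (0.99 log units; beyond the scatter), a modest step beyond the scatter. Both of these steps place a methoxy group on the pendant phenyl ring of the shared core.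

Compound 4 `CC(=O)Nc1ccc2oc(-c3ccc(C(F)(F)F)cc3)cc(=O)c2c1` differs from compound 1 as follows: trifluoromethyl in place of hydrogen on an aromatic carbon. For the measured compounds named here, no measured step puts a trifluoromethyl group anywhere, so the two methoxy steps are the only guide. They show that decorating the phenyl ring can lower the number by a modest amount or leave it unchanged, depending on where the group sits. The step from compound 1 to compound 4 is therefore expected to be small to modest and downward, a 2.4-fold lower number from compound 1 to compound 4 (0.38 log units; beyond the scatter). In this assay compound 4 is estimated at 40000 nM, with a likely range from 12000 nM to 110000 nM.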

Compound 4, half-maximal inhibitory concentration: 10000 nM
The estimate for compound 4 lay 4.0-fold (0.60 log units) above the measured number; the whole stated range lies above it.
By their numbers in this assay, from the lowest: compounds 3 and 4 (each within the scatter of the next); then compounds 2 and 1 (each within the scatter of the next).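

Trifluoromethyl, on an aromatic carbon para to a large group, gives a 9.7-fold lower number from compound 1 to compound 4 (0.99 log units; beyond the scatter), so this change lowers the number by a step that lies beyond the scatter. The earlier compounds shown here showed only methoxy groups on the pendant phenyl ring, and neither of them carried a group at this place; compound 4 shows that a group other than methoxy can also produce a step beyond the scatter on this ring. Nothing among the data shown accounts for the size of this step.

It remains open whether the step belongs to trifluoromethyl itself or to this place on the ring, as no other group stands here among the compounds shown. An amine, a carboxylic acid or a chloro group at the same carbon could settle that question.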